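The source may hold more compounds than are shown below. What is called first, only, known or untested is meant among the compounds shown, and "the series" means these compounds.

Measured so far:
compound 1 `COc1cc(-c2nc3cc(/C=C4\SC(=O)N(CC(=O)N5CCOCC5)C4=O)ccc3[nH]2)cc(OC)c1OC`: 2930 nM
compound 2 `COc1cc(-c2nc3cc(/C=C4\SC(=O)N(Cc5ccccc5)C4=O)ccc3[nH]2)cc(OC)c1OC`: 670 nM

In a functional assay on A549 cells (Homo sapiens) for inhibition, read by MTT assay, with a stated time of 48 h (a higher number here means a weaker inhibitor, a lower number a stronger inhibitor), compound 2 gives 670 nM, the lowest of the two numbers, and compound 1 gives 2930 nM. Going by the values given here, the only measured step, a 4.4-fold lower number from compound 1 to compound 2 (0.64 log units; beyond the scatter), lies beyond the scatter. Compound 3 `COc1cc(CN2C(=O)S/C(=C\c3ccc4[nH]c(-c5cc(OC)c(OC)c(OC)c5)nc4c3)C2=O)cc(OC)c1OC` has not been measured; it differs from compound 2 in that (3,4,5-trimethoxyphenyl in place of phenyl on a saturated chain carbon bound to an amide-type nitrogen in a ring). Among the compounds with values here, no measured pair exchanges phenyl for 3,4,5-trimethoxyphenyl at this place, and the step of a 4.4-fold lower number from compound 1 to compound 2 (0.64 log units; beyond the scatter) swaps the whole group rather than decorating it, so it bears only loosely on the change. With compound 2 as the sole anchor, no step beyond the scatter is expected in this assay in either direction. For compound 3 the value expected in this assay is 900 nM, within 300 nM to 2700 nM. The expected step is therefore a 1.3-fold higher number from compound 2 to compound 3 (0.13 log units; within the scatter).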

Compound 3, half-maximal inhibitory concentration: 530 nM
Beside the measured number, compound 3's estimate is 1.7-fold (0.23 log units) above it, and the stated range covers the measured number.
By their numbers in this assay, from the lowest: compounds 3 and 2 (each within the scatter of the next); then compound 1.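

In this assay, 3,4,5-trimethoxyphenyl in place of phenyl on the saturated chain carbon bound to an amide-type nitrogen in a ring gives a 1.3-fold lower number from compound 2 to compound 3 (0.10 log units; within the scatter) and so leaves compound 3 and compound 2 indistinguishable: this position accepts the larger, methoxy-decorated aromatic ring without a readable change. The exchange of (morpholin-4-yl)carbonyl for the same group gives a 5.5-fold lower number from compound 1 to compound 3 (0.74 log units; beyond the scatter) and, like the phenyl exchange before it, stands clear of the scatter, so the two benzyl-type compounds sit together apart from compound 1. No supporting evidence is available to explain these results.

Going by these compounds, whether a single methoxy group on the phenyl ring would behave in the same way remains open. So does the outcome for a longer chain carrying the phenyl ring, or for an amine or a carboxylic acid at this place.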